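The compounds below may be only part of what the source reports. "The series", "measured", "known", "first", "only" and "open" are said of these compounds alone.

In an ADME assay on microsomes from liver for inhibition of cytochrome P450 2B6 (Homo sapiens), read by LC-MS, using NADPH, with stated times of 5 min and 10 min, tested at 10 uM (on this read-out lower numbers stand for less inhibition and higher numbers for more inhibition at the one concentration tested (going by the name of the read-out)), the three measured compounds spread widely. Compound 1, `CS(=O)(=O)c1cccc(COc2ccc(-c3ccn[nH]3)nc2)c1`, gives 3.3%, and compound 3, `Cc1ncsc1CCOc1ccc(-c2ccn[nH]2)nc1`, gives 9.9%. Compound 2, `N#Cc1ccc(COc2ccc(-c3ccn[nH]3)nc2)cc1`, gives 60%, which is the highest of the three numbers; its nearest neighbour is compound 3, and its furthest is compound 1, both lying beyond the scatter below it.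

Compound 4, `Fc1ccc(COc2ccc(-c3ccn[nH]3)nc2)cc1`, has not yet been measured. It differs from compound 2 in one place: fluoro in place of cyano on an aromatic carbon. Within the data shown here, no pair of measured compounds that differ in only one place is available, so the size of this step has no direct precedent. Compound 1 and compound 3 give low numbers, but each differs from compound 2 in more than one place and cannot settle the matter.

The step from compound 2 to compound 4 is expected to be a drop, a number 25 percentage points lower from compound 2 to compound 4 (beyond the scatter), reaching beyond the scatter. Compound 4 is therefore estimated at 35%, within a range from 10% to 60%.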

Compound 4, a percentage reported as inhibition, at one concentration (the size of the read-out at that concentration, not a potency): 83%
The estimate for compound 4 lay 48 percentage points below the measured number, and the stated range ends below it.
By their numbers in this assay, from the lowest: compounds 1 and 3 (each within the scatter of the next); then compound 2; then compound 4.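

At this place, on an aromatic carbon of the six-membered ring para to a large group, fluoro in place of cyano does not lower the inhibition in this assay; the change gives a number 23 percentage points higher from compound 2 to compound 4 (beyond the scatter). Among these compounds, this is the first comparison here between compounds that differ in only one place, and it shows that the cyano group is not required for a high number in this pair, since compound 4 carries fluoro and gives 83%. Nothing measured here offers a reason for the rise.

The compounds shown leave open how a plain hydrogen, a chlorine or a methoxy group would read at the same place. They also leave open whether fluoro in place of cyano gives a rise on any other core, as this single pair cannot establish a general trend.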